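A chloro end on the butyl chain of compound 3

The source may hold more compounds than are shown below. What is called first, only, known or untested is meant among the compounds shown, and "the series" means these compounds.

Of the compounds shown here, three built on one shared core have been measured in a functional assay on HeLa cells (Homo sapiens) for antiproliferative activity, read by sulforhodamine B assay, with a stated time of 48 h; a higher number here means a weaker inhibitor of growth, a lower number a stronger inhibitor of growth. Compound 1 `O=C1COc2ccccc2N1CCCn1cc(-c2ccccc2)nn1` gives 9000 nM. Compound 2 `O=C1COc2ccccc2N1CCCn1cc(-c2cccnc2)nn1` gives > 100000 nM, which is a limit of the assay and not a number. Compound 3 `CCCCc1cn(CCCN2C(=O)COc3ccccc32)nn1` gives 1020 nM, the lowest of the numbers in hand.

Compound 4 `O=C1COc2ccccc2N1CCCn1cc(CCCCl)nn1` differs from compound 3 in one place: chloro in place of methyl on a saturated chain carbon, three bonds along the chain from an aromatic carbon. The same difference reads butyl to 3-chloropropyl. Going by the values given here, three measured steps bear on this group, all of them replacing the whole substituent on an aromatic carbon. The step of an at least 11-fold higher number from compound 1 to compound 2 (1.04 log units; beyond the scatter) was large, the step of an at least 98-fold lower number from compound 2 to compound 3 (1.99 log units; beyond the scatter) was large too, and the step of an 8.8-fold lower number from compound 1 to compound 3 (0.95 log units; beyond the scatter) was modest. None of them changes only the end of a saturated chain, so they show that this place matters but give no direct measure of the new change. Since the butyl chain stays almost whole, a much smaller step is expected here, most likely none beyond the scatter, with a slight lean upward. The expected change is a 1.4-fold higher number from compound 3 to compound 4 (0.14 log units; within the scatter). For compound 4 the estimated value in this assay is 1400 nM, with a range from 450 nM to 5000 nM.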

Compound 4, concentration for 50% growth inhibition: 100 nM
Compound 4: the middle estimate sits 14-fold (1.15 log units) above what was measured; measured number below the stated range.
By their numbers in this assay, from the lowest: compound 4; then compound 3; then compound 1. At a limit, above all of these: compound 2.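

In this assay, going by these compounds alone, the far end of the chain proves to matter on its own: chloro in place of methyl gives a 10-fold lower number from compound 3 to compound 4 (1.01 log units; beyond the scatter), whereas the earlier steps replaced the whole substituent on the aromatic carbon and could not show that so small an exchange has a large effect. With 3-chloropropyl on the shared core in place of phenyl, the result is a 90-fold lower number from compound 1 to compound 4 (1.95 log units; beyond the scatter), so a saturated chain ending in chloro goes well past the phenyl compound, and past the butyl compound as well. Compound 2 stands at a limit and not a number, which makes an at least 1000-fold lower number from compound 2 to compound 4 (3.00 log units; beyond the scatter) a bound and not a measured gap: the limit of > 100000 nM in this assay, at which 1 of the 4 values shown sits.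

From the compounds shown here alone, what a bromo, hydroxyl or amine end on the same chain would do remains open, so the gain cannot yet be assigned to chloro as such rather than to any replacement of methyl. Going by these compounds, how 2-chloroethyl or a longer chain ending in chloro would compare with 3-chloropropyl is equally open, which leaves the best distance of the chloro end from the aromatic carbon undefined.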